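The source may report more compounds than this note shows. Statements on the series, on what has been measured and on what is new or still open speak of the compounds shown alone.

In a functional assay on MGC-803 cells (Homo sapiens) for antiproliferative activity, read by CCK-8 assay, with a stated time of 72 h (on this read-out lower numbers stand for stronger inhibition and higher numbers for weaker inhibition), compound 3 `Nc1ccccc1NC(=O)c1ccc(COc2ccc(Cl)cc2)cc1` gives > 32000 nM as a limit of the assay, not a number. Compound 1 `Nc1ccccc1NC(=O)c1ccc(COc2ccc([N+](=O)[O-])cc2)cc1` gives > 32000 nM as a limit too, and the limit of > 32000 nM in this assay, at which 2 of the 3 values shown sit, is all that the two values share. Compound 2 `O=C(NO)c1ccc(COc2ccccc2)cc1` gives "not determined" (no result reported) and offers no guide. The structural change leading to compound 4 `CCc1ccc(OCc2ccc(C(=O)Nc3ccccc3N)cc2)cc1` is ethyl in place of chloro on an aromatic carbon, with ethyl in place of chloro on an aromatic carbon. Among the measured compounds shown here, the one measured step that bears on it, a step that the two limits leave unreadable from compound 1 to compound 3, also changes that aromatic carbon but has no readable size. No step beyond the scatter is therefore expected in this assay, and the estimated change is a number no higher from compound 3 to compound 4 (the limit leaves the size open) as the expected step. Compound 4 is expected at about 32000 nM, with an estimated range from 12000 nM to 64000 nM here.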

Compound 4, half-maximal inhibitory concentration: 5880 nM
For compound 4 the middle estimate is 5.4-fold (0.74 log units) above the measured one; measured number outside the range, below it.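

In this assay, among the compounds shown here, compound 4 gives the only readable steps at the aromatic carbon para to a large group: ethyl in place of chloro brings an at least 5.4-fold lower number from compound 3 to compound 4 (0.73 log units; beyond the scatter), and ethyl in place of nitro brings an at least 5.4-fold lower number from compound 1 to compound 4 (0.73 log units; beyond the scatter). The assay's response therefore depends on the group at this position, which compound 1 and compound 3 alone could not show. Both steps give only a minimum size because compound 1 and compound 3 are limits of the assay: the limit of > 32000 nM in this assay, at which 2 of the 4 values shown sit.

From the compounds shown here alone, whether a longer chain, a methoxy group or an amine at this position would lower the number further remains open.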